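This account rests on a few compounds, and the source may have more. Where it says the series, first, only, none or still open, it means among the compounds named here.

Of the compounds shown here, three have so far been measured in an assay on isolated protein for inhibition of Amine oxidase [flavin-containing] B (Homo sapiens), read by fluorescence, with stated times of 15 min and 20 min; on this read-out higher numbers stand for weaker inhibition and lower numbers for stronger inhibition. Compound 1 `CC(C)(C)c1cc(C(=O)NCCC2CCN(Cc3ccccc3)CC2)cc(C(C)(C)C)c1O` gives 89200 nM in this assay. Compound 2 `CC(C)(C)c1cc(/C=C/C(=O)NCC2CCN(Cc3ccccc3)CC2)cc(C(C)(C)C)c1O` gives 11700 nM in this assay. Compound 3 `CC(C)(C)c1cc(/C=C/C(=O)NCCC2CCN(Cc3cccc(F)c3)CC2)cc(C(C)(C)C)c1O` gives 6500 nM in this assay, the lowest of the three numbers shown, although its gap from compound 2 lies within the usual scatter of repeated measurements, and only its gap from compound 1 lies beyond that scatter.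

Compound 4 `CC(C)(C)c1cc(/C=C/C(=O)NCCC2CCN(Cc3ccc(Br)cc3)CC2)cc(C(C)(C)C)c1O` has not yet been measured. It differs from compound 3 in one place: 4-bromophenyl in place of 3-fluorophenyl on a saturated chain carbon bound to an amine nitrogen in a ring. For the measured compounds named here, no pair of measured compounds in this set differs by a change of this kind, so there is no measured precedent for the step. The leaving and entering groups are both a halogen-bearing phenyl of the same count of heavy atoms, so the step from compound 3 to compound 4 is expected to be small, a 1.2-fold lower number from compound 3 to compound 4 (0.07 log units; within the scatter), and not to exceed the scatter in either direction. Compound 4 is therefore estimated at 5500 nM in this assay, with a range from 1800 nM to 17000 nM.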

Compound 4, half-maximal inhibitory concentration: 13200 nM
The estimate for compound 4 lay 2.4-fold (0.38 log units) below the measured number, and the stated range covers the measured number.
By their numbers in this assay, from the lowest: compounds 3, 2 and 4 (each within the scatter of the next, the first and the last beyond it); then compound 1.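

In this assay, putting 4-bromophenyl in place of 3-fluorophenyl on a saturated chain carbon bound to an amine nitrogen in a ring gives a 2.0-fold higher number from compound 3 to compound 4 (0.31 log units; beyond the scatter). For the compounds shown here, this is the first step that can be read at this position, and it shows that the read-out responds, modestly and towards weaker inhibition, to exchanging one halogen-bearing phenyl for another of the same heavy-atom count. No measurement at hand bears on why the number moves.

The halogen and its place on the phenyl both differ between compound 3 and compound 4, so the compounds shown leave open which of the two carries the step. They also leave open how a pyridyl or cyclohexyl group would read in that place.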